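Swapping the amine on the side chain of compound 1

The source may report more compounds than this note shows. Statements on the series, on what has been measured and on what is new or still open speak of the compounds shown alone.

In a functional assay on A549 cells (Homo sapiens) for cytotoxicity, read by MTT assay, with a stated time of 48 h (on this read-out higher numbers stand for weaker inhibition and lower numbers for stronger inhibition), compound 1 `COc1c(OCCCCNCc2ccccc2)cc(O)c2c(=O)cc(-c3ccccc3)oc12` gives 4590 nM. Going by the values given here, this is the only number so far, so it cannot yet be ranked as high or low. Compound 2 `COc1c(O)cc(O)c2c(=O)cc(-c3ccc(F)cc3)oc12` offers no comparison: its entry reads "not determined" (no result reported).

Compound 3 `CCN(CC)CCCOc1cc(O)c2c(=O)cc(-c3ccccc3)oc2c1OC` has not yet been measured. It differs from compound 1 at one place: diethylamino in place of (benzylamino)methyl on a saturated chain carbon, three bonds along the chain from an oxygen on an aromatic ring. In words, diethylamino stands in place of (benzylamino)methyl on a saturated chain carbon, three bonds along the chain from an oxygen on an aromatic ring. The six-membered aromatic ring of the departing group is therefore lost, while the shared core stays unchanged.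

Among the compounds with values here, no measured pair shows what such a change does, so the expectation rests only on compound 1 at 4590 nM and carries a wide range. A modest loss of activity in this assay is expected, not far beyond the scatter, and the estimated step is a 1.7-fold higher number from compound 1 to compound 3 (0.24 log units; within the scatter). For compound 3 the expected value is 8000 nM, with an estimated range from 2800 nM to 24000 nM.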

Compound 3, half-maximal inhibitory concentration: 1830 nM
Beside the measured number, compound 3's estimate is 4.4-fold (0.64 log units) above it; the whole stated range lies above it.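

In this assay, diethylamino in place of (benzylamino)methyl on a saturated chain carbon, three bonds along the chain from an oxygen on an aromatic ring, gives a 2.5-fold lower number from compound 1 to compound 3 (0.40 log units; beyond the scatter). Going by these compounds alone, this is the first reading at this position, and the change is a modest gain in inhibition that lies beyond the scatter. At least for this pair, the six-membered aromatic ring of the departing group is not needed to keep the activity, and the entering group, with no ring and no hydrogen-bond donors, does better on this read-out. No measured property in hand bears on why the number moves in this direction.

A single pair changes the ring, the group size and the hydrogen-bond donor together, so it cannot say which of these differences goes with the lower number. Still open, going by these compounds, is how a cyclic amine such as piperidine or morpholine would read on the same chain, and whether dimethylamino or a longer chain carrying diethylamino would extend or reverse the step.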